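This account rests on a few compounds, and the source may have more. Where it says the series, first, only, none or still open, it means among the compounds named here.

Measured so far in a functional assay on SK-OV-3 cells (Homo sapiens) for cytotoxicity; on this read-out lower numbers stand for an effect already at smaller amounts and higher numbers for an effect only at larger amounts of compound:
compound 1 `CCCCC/C=C\C[C@@H](O)[C@H](O)/C=C/[C@@H]1C/C=C\CCCC(=O)O1` gives 12.3 ug/mL
compound 2 `CC/C=C\C/C=C\C[C@@H](O)[C@H](O)/C=C/[C@@H]1C/C=C\CCCC(=O)O1` gives 4.2 ug/mL
compound 3 `CCCCC/C=C\C[C@H](O)C(/C=C/[C@@H]1C/C=C\CCCC(=O)O1)OC` gives 13 ug/mL

Compound 2 differs from compound 1 by but-1-en-1-yl in place of butyl on a saturated chain carbon bound to a double-bonded chain carbon. In this assay this change produced a 2.9-fold lower number from compound 1 to compound 2 (0.47 log units; beyond the scatter), a modest step but one beyond the usual scatter. Compound 3 stands on a different core; how its core differs from that of compound 1 is not broken down here, and the values of compound 1 and compound 3 in this assay lie within the scatter of each other, so no order between them can be claimed.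

Compound 4 `CC/C=C\C/C=C\C[C@H](O)C(/C=C/[C@@H]1C/C=C\CCCC(=O)O1)OC` has not yet been measured. It is the counterpart of compound 3 carrying (but-1-en-1-yl in place of butyl on a saturated chain carbon bound to a double-bonded chain carbon), the same change, at the same place, that leads from compound 1 to compound 2. Because a 2.9-fold lower number from compound 1 to compound 2 (0.47 log units; beyond the scatter) was seen once for this change, a step of similar size is expected here, so the step from compound 3 to compound 4 in this assay is estimated as a 2.9-fold lower number from compound 3 to compound 4 (0.46 log units; beyond the scatter). Compound 4 is therefore expected to give 4.5 ug/mL in this assay, within a range from 2.2 ug/mL to 10 ug/mL; with a single measured instance of this change behind it, the range is kept wide.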

Compound 4, concentration for half-maximal effect: 5.1 ug/mL
The estimate for compound 4 lay 1.1-fold (0.05 log units) below the measured number; low and high end bracket the measured number.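

In this assay, but-1-en-1-yl in place of butyl on a saturated chain carbon bound to a double-bonded chain carbon again gave a step beyond the scatter, a 2.5-fold lower number from compound 3 to compound 4 (0.41 log units; beyond the scatter), so the change carried over to the second core. Set beside the earlier step, the two agree in direction and cannot be told apart in size: the same change on two cores in this assay, a 2.9-fold lower number (0.47 log units; beyond the scatter) from compound 1 to compound 2 and a 2.5-fold lower number (0.41 log units; beyond the scatter) from compound 3 to compound 4, 1.1-fold (0.06 log units) apart, within the scatter of two such steps. This shows that the step transferred between these two cores on these cells, but it rests on one pair per core and does not show that the change would behave alike on any other core, nor does it explain why the number falls.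

The compounds shown leave open how far the trend runs along the chain, since a longer chain, or a third double bond in it, does not appear among them. They also leave open what a chain bearing an amine or a carboxylic acid would give in this series.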